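Swapping a Pyridine for a Fluorophenyl Ether

The source may hold more compounds than are shown below. What is called first, only, known or untested is meant among the compounds shown, and "the series" means these compounds.

Compound 2 `O=c1cc(-n2cc(COc3cccnc3)nn2)c2cc(Br)ccc2o1` gives 39800 nM in a functional assay on MCF7 cells (Homo sapiens) for antiproliferative activity, read by MTT assay, with a stated time of 48 h; a lower number here means a stronger inhibitor, a higher number a weaker inhibitor. Among the three numbers measured it stands second highest: compound 3 `O=c1cc(-n2cc(COc3ccnc4ccc(Br)cc34)nn2)c2cc(Br)ccc2o1` gives 41600 nM, which is within the scatter of compound 2, while compound 1 `O=c1cc(-n2cc(-c3ccccc3)nn2)c2cc(Br)ccc2o1` gives 9450 nM, and the step of a 4.2-fold higher number from compound 1 to compound 2 (0.62 log units; beyond the scatter) is the only one beyond the scatter. Compound 4 `O=c1cc(-n2cc(COc3ccc(F)cc3)nn2)c2cc(Br)ccc2o1` differs from compound 2 in one place: 4-fluorophenyl in place of pyridin-3-yl on an oxygen on a saturated carbon. Among the measured compounds shown here, no measured step makes this exact change. For the measured compounds named here, the values of compound 2 and compound 3 show that exchanging the pyridin-3-yl for a different ring barely moved the number, and the one clear step concerns another part of the molecule. The expected step of a 1.3-fold lower number from compound 2 to compound 4 (0.12 log units; within the scatter) is therefore small, within the scatter. Compound 4 is estimated at 30000 nM, with a range from 12000 nM to 80000 nM.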

Compound 4, half-maximal inhibitory concentration: 7000 nM
Compound 4: middle estimate off by 4.3-fold (0.63 log units), on the high side; measured number outside the range, below it.
By their numbers in this assay, from the lowest: compounds 4 and 1 (each within the scatter of the next); then compounds 2 and 3 (each within the scatter of the next).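

The ring on this oxygen is not a silent position: the step of a 5.7-fold lower number from compound 2 to compound 4 (0.75 log units; beyond the scatter) comes from 4-fluorophenyl in place of pyridin-3-yl. The near-equal values of compound 2 and compound 3 had not shown that a change of this ring could move the number beyond the scatter. Nothing shown explains the step.

The compounds shown leave open whether the fluorine or the loss of the ring nitrogen carries this step. A plain phenoxy or a 4-methoxyphenoxy group at this place would help separate the two.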